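Microsomal stability notes: step from compound 2 to compound 3

The source may report more compounds than this note shows. Statements on the series, on what has been measured and on what is new or still open speak of the compounds shown alone.

Measured so far:
compound 1 `CCCN(C[C@H]1Cc2c(cccc2N2CCNCC2)CN1)[C@H]1CCCc2cccnc21`: 87.4%
compound 2 `CN(C[C@H]1Cc2c(cccc2N2C[C@@H]3C[C@H]2CN3)CN1)[C@H]1CCCc2cccnc21`: 36.3%

Both numbers come from an ADME assay on microsomes from liver (Mus musculus) for metabolic stability, read by LC-MS, with a stated time of 10 min; a higher number here means that more of the compound is left, a lower number that less of the compound is left. Compound 2 stands lowest of the two values; its nearest neighbour is compound 1, which sits higher by a margin beyond the scatter. Among the compounds with values here, compound 1 differs from compound 2 in more than one place, so no single step between them is defined; the two values only show what each compound gives.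

Compound 3 `CN(C[C@H]1Cc2c(cccc2N2CCNC(C)(C)C2)CN1)[C@H]1CCCc2cccnc21` is not yet measured. It differs from compound 2 in one place: a group of 8 heavy atoms (6 carbon, 2 nitrogen; one six-membered non-aromatic ring with 2 hetero atoms) in place of a group of 7 heavy atoms (5 carbon, 2 nitrogen; 2 five-membered non-aromatic rings with 1 hetero atom each), on an aromatic carbon. Everything else in the molecule is unchanged.

Within the data shown here, no measured pair isolates this change, so any expectation rests on the two numbers alone. Because compound 1 gives 87.4% while compound 2 gives 36.3%, the series shows room for higher values, and a rise is expected for compound 3, though of uncertain size. The step from compound 2 to compound 3 is expected at a number 18.7 percentage points higher from compound 2 to compound 3 (beyond the scatter), upward and beyond the scatter. Compound 3 is estimated at 55%, with a range from 30% to 80%.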

Compound 3, percent of the compound remaining: 44%
The estimate for compound 3 lay 11 percentage points above the measured number; the range from low to high includes it.
By their numbers in this assay, from the lowest: compounds 2 and 3 (each within the scatter of the next); then compound 1.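

In this assay the series now holds its first step that changes one place, a number 7.7 percentage points higher from compound 2 to compound 3 (within the scatter), at an aromatic carbon of the shared core. The group that leaves and the 3,3-dimethylpiperazin-1-yl group that enters have the same counts of hydrogen-bond donors and acceptors and no net charge, so at this position a different ring skeleton with those counts held gives no change that this read-out can resolve. Nothing at hand speaks to the reason for this result.

Within the data shown here, compound 2 and compound 3 each differ in more than one place from compound 1, which gives 87.4% in this assay, so no step to it can be read, and the propyl chain of compound 1 cannot be separated from the ring group it carries. From the compounds shown here alone, how a morpholin-4-yl ring or a 4-methylpiperazin-1-yl group at the same aromatic carbon would read in this assay stays open, as does the effect of a propyl chain in place of the methyl group on compound 3 alone.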